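A Second Fluoro on Compound 3

The source may hold more compounds than are shown below. What is called first, only, known or untested is meant among the compounds shown, and "the series" means these compounds.

In a functional assay on HL-60 cells (Homo sapiens) for cytotoxicity, read by WST assay, with a stated time of 48 h (on this read-out lower numbers stand for an effect already at smaller amounts and higher numbers for an effect only at larger amounts of compound), compound 1 (`Cc1ccccc1C[C@H]1C(=O)OC[C@@H]1Cc1ccccc1`) gives 57000 nM, compound 2 (`O=C1OC[C@H](Cc2ccccc2)[C@H]1Cc1cccc(F)c1`) gives 75000 nM and compound 3 (`O=C1OC[C@H](Cc2ccccc2)[C@H]1Cc1ccc(F)cc1`) gives 57000 nM. Compound 3 thus stands level with compound 1 at the digits shown, and compound 2 lies within the scatter of both.

Compound 4 (`O=C1OC[C@H](Cc2ccccc2)[C@H]1Cc1ccc(F)c(F)c1`) differs from compound 3 by one change: fluoro in place of hydrogen on an aromatic carbon. This places fluoro in place of hydrogen on an aromatic carbon, ortho to a fluoro group and meta to a large group. Among the measured compounds shown here, no measured step makes this exact kind of change. The closest evidence comes from exchanges on the same substituted phenyl: a 1.3-fold lower number from compound 2 to compound 3 (0.12 log units; within the scatter), a 1.3-fold higher number from compound 1 to compound 2 (0.12 log units; within the scatter) and no change at the digits printed from compound 1 to compound 3 (within the scatter), all within the scatter. On that evidence, no step beyond the scatter is expected in this assay, in either direction. The expected step is a 1.0-fold lower number from compound 3 to compound 4 (0.02 log units; within the scatter). For compound 4 the estimated value is 55000 nM, with an expected range of 28000 nM to 110000 nM.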

Compound 4, half-maximal effective concentration: 50000 nM
Compound 4: middle estimate off by 1.1-fold (0.04 log units), on the high side; the measured number falls inside the stated range.
By their numbers in this assay, from the lowest: compounds 4, 1, 3 and 2 (each within the scatter of the next).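

In this assay, among the compounds shown here, the first direct reading of fluoro in place of hydrogen on an aromatic carbon, ortho to a fluoro group and meta to a large group, is a 1.1-fold lower number from compound 3 to compound 4 (0.06 log units; within the scatter), and the same kind of change read from the other single-fluoro compound is a 1.5-fold lower number from compound 2 to compound 4 (0.18 log units; within the scatter). Neither step leaves the scatter, so on these compounds a second fluoro on this phenyl is accepted without a readable change in the number. Nothing measured here bears on why this is so.

On these data alone, whether a group other than fluoro at this position, such as an amine, a methoxy or a carboxylic acid, would move the number beyond the scatter remains open. Also open, as far as these compounds go, is whether the second phenyl, unsubstituted in all four compounds, would respond to any such group.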